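This account rests on a few compounds, and the source may have more. Where it says the series, first, only, none or still open, it means among the compounds named here.

Compound 1, `COc1ccc(S(=O)(=O)Nc2cccc3[nH]nc(Cl)c23)cc1`, was tested in a functional assay on A549 cells (Homo sapiens) for cytotoxicity, read by MTT assay, with a stated time of 72 h; on this read-out higher numbers stand for weaker inhibition and lower numbers for stronger inhibition. In this assay compound 1 gives 1830 nM. Compound 2, `CCOc1ccc(NS(=O)(=O)c2ccc(OC)cc2)c2c(Cl)n[nH]c12`, keeps the core of compound 1 and differs from it in one place: ethoxy in place of hydrogen on an aromatic carbon. In this assay compound 2 gives 5830 nM, so the change produced a 3.2-fold higher number from compound 1 to compound 2 (0.50 log units; beyond the scatter), a move toward weaker inhibition.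

Compound 3, `C=CCn1cc2ccc(NS(=O)(=O)c3ccc(C)cc3)cc2n1`, is built on a different core; the difference between the two cores is not broken down here. In this assay compound 3 gives 11900 nM, the highest number among the three measured compounds. Compound 4, `C=CCn1cc2ccc(NS(=O)(=O)c3ccc(C)cc3)c(OCC)c2n1`, has not yet been measured. It differs from compound 3 in one place: ethoxy in place of hydrogen on an aromatic carbon. Within the data shown here, this is the same kind of change as the one between compound 1 and compound 2, but not the same change: in compound 2 the new group sits para to a large group, while in compound 4 it sits ortho to a large group, and the core around it is different as well.

Among the measured compounds shown here, only one earlier example of this change exists, so any expectation rests on it alone. For compound 4 the expected step is a 2.5-fold higher number from compound 3 to compound 4 (0.40 log units; beyond the scatter), because the earlier case gave a 3.2-fold higher number from compound 1 to compound 2 (0.50 log units; beyond the scatter) and nothing measured here argues for a different direction. Compound 4 is estimated at 30000 nM, within a range from 12000 nM to 80000 nM, and a number this high may leave the assay reporting only a limit.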

Compound 4, half-maximal inhibitory concentration: > 100000 nM
Compound 4: a limit, no number; the forecaster's own chance of this, stated with the estimate: 25%; at least 3.3-fold (0.52 log units) between middle value and limit.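

In this assay, putting ethoxy in place of hydrogen on an aromatic carbon gave an at least 8.4-fold higher number from compound 3 to compound 4 (0.92 log units; beyond the scatter), a move toward weaker inhibition, just as the same change was on the core of compound 1. Compound 4 gives > 100000 nM, which is a limit of the assay and not a number. The direction of the change therefore carried over from one core to the other, but these results do not show whether its size carried over as well: the same change on two cores in this assay, a 3.2-fold higher number (0.50 log units; beyond the scatter) from compound 1 to compound 2 and an at least 8.4-fold higher number (0.92 log units; beyond the scatter) from compound 3 to compound 4; the limit leaves it open whether they differ

As far as these compounds go, it remains open whether a hydroxyl group, an amine or a carboxylic acid at the same place on the core of compound 3 would give a measurable number in this assay, and how such a number would compare with that of compound 3. From the compounds shown here alone, two cores are also only two cases, and in compound 4 the ethoxy sits ortho to a large group, so it is unknown whether the same direction would hold on further cores or at other places on the ring.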